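The source may hold more compounds than are shown below. What is called first, only, known or untested is meant among the compounds shown, and "the series" means these compounds.

The series shares the core seen in compound 1 `C=C(Br)C(=O)Nc1cccc(-c2cn3nc(Cc4cccc(OC)c4)sc3n2)c1`, whose number in a functional assay on CCRF-CEM cells (Homo sapiens) for inhibition, read by cell counting, with a stated time of 3 days (a lower number here means a stronger inhibitor, a higher number a weaker inhibitor), is 3100 nM. Compound 2 `C=C(Br)C(=O)Nc1cccc(-c2cn3nc(Cc4ccc(OC)cc4)sc3n2)c1` gives 2300 nM in this assay, a step of a 1.3-fold lower number from compound 1 to compound 2 (0.13 log units; within the scatter). Compound 3 `C=C(Br)C(=O)Nc1cccc(-c2cn3nc(-c4ccccc4)sc3n2)c1` gives 960 nM in this assay, the lowest of the three numbers, reached by steps of a 3.2-fold lower number from compound 1 to compound 3 (0.51 log units; beyond the scatter) and a 2.4-fold lower number from compound 2 to compound 3 (0.38 log units; beyond the scatter). Compound 4 `C=C(Br)C(=O)Nc1cccc(-c2cn3nc(-c4cccs4)sc3n2)c1` has not yet been measured in this assay. Its difference from compound 3 is thiophen-2-yl in place of phenyl on an aromatic carbon. Among the compounds with values here, the two measured steps at this position both exchanged a methoxybenzyl group for phenyl and were modest in size; no measured step exchanges one aromatic ring for another of comparable size, so they bear on the new change only loosely. Because compound 3 sits at 960 nM and the replacement keeps an aromatic ring at the same position, compound 4 is expected to give a number close to it, with a step of a 1.0-fold higher number from compound 3 to compound 4 (0.02 log units; within the scatter) that lies within the scatter. The estimate for compound 4 is 1000 nM, ranging from 400 nM to 2500 nM.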

Compound 4, half-maximal inhibitory concentration: 410 nM
Beside the measured number, compound 4's estimate is 2.4-fold (0.39 log units) above it; the range from low to high includes it.
By their numbers in this assay, from the lowest: compound 4; then compound 3; then compounds 2 and 1 (each within the scatter of the next).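

In this assay, this position on the five-membered aromatic ring responds not only to the loss of a methoxybenzyl group but also to the exchange of one aromatic ring for another: thiophen-2-yl in place of phenyl gives a 2.3-fold lower number from compound 3 to compound 4 (0.37 log units; beyond the scatter). Set against the two methoxybenzyl compounds, the same group gives a 5.6-fold lower number from compound 2 to compound 4 (0.75 log units; beyond the scatter) and a 7.6-fold lower number from compound 1 to compound 4 (0.88 log units; beyond the scatter), which makes compound 4 the strongest inhibitor of the four. No evidence is at hand to account for the difference between the thiophen-2-yl and phenyl rings.

As far as these compounds go, whether thiophen-3-yl, furan-2-yl or pyridin-2-yl at this carbon would lower the number further remains open. So does the effect of an amine or a carboxylic acid placed on the thiophene ring.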